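Chain homologation and amide ring swap in a tetrazole series

The source may hold more compounds than are shown below. What is called first, only, known or untested is meant among the compounds shown, and "the series" means these compounds.

Compound 2 `CCCCc1nc(C)c(CC(=O)N2CCOCC2)c(=O)n1Cc1ccc(-c2ccccc2-c2nnn[nH]2)cc1` gives 0.018 mg/kg in an in vivo functional assay on the whole organism for inhibition, with Rattus norvegicus as the target; on this read-out lower numbers stand for an effect already at smaller amounts and higher numbers for an effect only at larger amounts of compound. Compound 1 `CCCCc1nc(C)c(CC(=O)N2CCCC2)c(=O)n1Cc1ccc(-c2ccccc2-c2nnn[nH]2)cc1` differs by pyrrolidin-1-yl in place of morpholin-4-yl on a carbonyl carbon and gives 0.056 mg/kg in this assay, a step of a 3.1-fold higher number from compound 2 to compound 1 (0.49 log units; beyond the scatter). Compound 3 `CCCCc1nc(C)c(CCC(=O)N2CCOCC2)c(=O)n1Cc1ccc(-c2ccccc2-c2nnn[nH]2)cc1` carries a longer chain, (((morpholin-4-yl)carbonyl)methyl in place of (morpholin-4-yl)carbonyl on a saturated chain carbon bound to an aromatic carbon), and gives 0.143 mg/kg in this assay; the steps are a 7.9-fold higher number from compound 2 to compound 3 (0.90 log units; beyond the scatter) and a 2.6-fold higher number from compound 1 to compound 3 (0.41 log units; beyond the scatter). Compound 4 `CCCCc1nc(C)c(CCC(=O)N2CCCC2)c(=O)n1Cc1ccc(-c2ccccc2-c2nnn[nH]2)cc1` is not yet measured; it differs from compound 3 by pyrrolidin-1-yl in place of morpholin-4-yl on a carbonyl carbon, the same change as from compound 2 to compound 1, on the core of compound 3 rather than that of compound 2. For the measured compounds named here, on the one precedent, a 3.1-fold higher number from compound 2 to compound 1 (0.49 log units; beyond the scatter), a similar weakening is expected for compound 4, giving a 2.9-fold higher number from compound 3 to compound 4 (0.47 log units; beyond the scatter). Going by the values given here, with only one pair behind it, the estimate for compound 4 in this assay is 0.42 mg/kg, between 0.15 mg/kg and 1.1 mg/kg.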

Compound 4, dose for half-maximal effect: 0.206 mg/kg
The estimate for compound 4 lay 2.0-fold (0.31 log units) above the measured number; the measured number falls inside the stated range.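

In this assay, the change to pyrrolidin-1-yl from morpholin-4-yl on the longer chain gives a 1.4-fold higher number from compound 3 to compound 4 (0.16 log units; within the scatter), but the two cores cannot be told apart on this change: the same change on two cores in this assay, a 3.1-fold higher number (0.49 log units; beyond the scatter) from compound 2 to compound 1 and a 1.4-fold higher number (0.16 log units; within the scatter) from compound 3 to compound 4, 2.2-fold (0.33 log units) apart, within the scatter of two such steps. The longer chain with pyrrolidin-1-yl gives a 3.7-fold higher number from compound 1 to compound 4 (0.57 log units; beyond the scatter), and the two changes together give an 11-fold higher number from compound 2 to compound 4 (1.06 log units; beyond the scatter). Two pairs show neither that the change carries over unaltered nor that its size depends on the core.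

Open, from the compounds shown here alone, is whether other amines on the carbonyl, such as piperidin-1-yl or dimethylamino, follow the same course on both cores. Also open, going by these compounds, is how a still longer chain carrying the amide would read out in this assay.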